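The compounds below may be only part of what the source reports. "The series", "measured", "known", "first", "only" and "open" are said of these compounds alone.

In a functional assay on NALM-6 cells (Homo sapiens) for inhibition, read by MTT assay, with a stated time of 48 h (on this read-out higher numbers stand for weaker inhibition and lower numbers for stronger inhibition), compound 2 `C=C1C(=O)N(c2ccccc2)N(C)C1c1ccccc1` gives 24400 nM, the lowest of the two numbers recorded, while compound 1 `C=C1CN(C)N(c2ccc(Cl)cc2)C1=O` gives 51900 nM, a gap beyond the scatter. Compound 3 `C=C1CN(C)N(c2ccccc2)C1=O` has not been measured. The change from compound 2 to compound 3 is hydrogen in place of phenyl on a saturated ring carbon. For the measured compounds named here, no measured pair shows this step; the step expected in this assay is a 1.8-fold higher number from compound 2 to compound 3 (0.27 log units; within the scatter), toward weaker inhibition, because compound 1 gives 51900 nM. Compound 3 is therefore estimated at 45000 nM, with a range from 20000 nM to 100000 nM.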

Compound 3, half-maximal inhibitory concentration: 56000 nM
Compound 3: the middle estimate sits 1.2-fold (0.09 log units) below what was measured; the measured number falls inside the stated range.
By their numbers in this assay, from the lowest: compound 2; then compounds 1 and 3 (each within the scatter of the next).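

In this assay, for the compounds shown here, hydrogen in place of phenyl on the saturated ring carbon gives a 2.3-fold higher number from compound 2 to compound 3 (0.36 log units; beyond the scatter), a modest step toward weaker inhibition and the first direct reading of this position. Hydrogen in place of chloro on an aromatic carbon gives a 1.1-fold higher number from compound 1 to compound 3 (0.03 log units; within the scatter), so this pair shows no change at that carbon. Nothing available gives a reason for either step.

From the compounds shown here alone, whether a smaller group such as methyl, or an amine, on the saturated ring carbon would keep the effect of phenyl remains open. So does the effect of a methoxy group on the aromatic carbon.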